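The source may hold more compounds than are shown below. What is called first, only, known or untested is meant among the compounds shown, and "the series" means these compounds.

Compound 3 `O=C1c2ccc(F)cc2C(=O)N1c1nc(-c2ccccc2)cs1` gives 40200 nM in a functional assay on PC-3 cells (Homo sapiens) for antiproliferative activity, read by MTT assay, with a stated time of 48 h (a lower number here means a stronger inhibitor, a higher number a weaker inhibitor), the lowest of the three numbers in hand, though compound 1 `O=C1c2ccccc2C(=O)N1c1nc(-c2ccccc2)cs1` at 43900 nM and compound 2 `O=C1c2ccccc2C(=O)N1c1nc(-c2ccc(Cl)cc2)cs1` at 44900 nM both lie within the scatter of it, so no order can be read among the three. Compound 4 `O=C1c2ccc(F)cc2C(=O)N1c1nc(-c2ccc(Cl)cc2)cs1` differs from compound 3 by chloro in place of hydrogen on an aromatic carbon. The same change appears once among the measured pairs: a 1.0-fold higher number from compound 1 to compound 2 (0.01 log units; within the scatter), a step that stayed within the scatter. The other measured step, a 1.1-fold lower number from compound 1 to compound 3 (0.04 log units; within the scatter), also stayed within the scatter. On that single matching precedent, the step is expected to be a 1.0-fold higher number from compound 3 to compound 4 (0.01 log units; within the scatter) in this assay, nothing beyond the scatter. Compound 4 is therefore estimated at 41000 nM, between 25000 nM and 70000 nM.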

Compound 4, half-maximal inhibitory concentration: 38000 nM
Compound 4: the middle estimate sits 1.1-fold (0.03 log units) above what was measured; the measured number falls inside the stated range.
By their numbers in this assay, from the lowest: compounds 4, 3, 1 and 2 (each within the scatter of the next).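

Replacing phenyl with 4-chlorophenyl has now been read on a second core, one carrying the fluoro group, and the step, a 1.1-fold lower number from compound 3 to compound 4 (0.02 log units; within the scatter), again changes nothing measurable: the same change on two cores in this assay, a 1.0-fold higher number (0.01 log units; within the scatter) from compound 1 to compound 2 and a 1.1-fold lower number (0.02 log units; within the scatter) from compound 3 to compound 4, 1.1-fold (0.03 log units) apart, within the scatter of two such steps

The fluoro change also gains a second reading, a 1.2-fold lower number from compound 2 to compound 4 (0.07 log units; within the scatter), on a core carrying the chloro group: the same change on two cores in this assay, a 1.1-fold lower number (0.04 log units; within the scatter) from compound 1 to compound 3 and a 1.2-fold lower number (0.07 log units; within the scatter) from compound 2 to compound 4, 1.1-fold (0.03 log units) apart, within the scatter of two such steps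

In this assay, each change therefore looks the same with or without the other.

Chloro and fluoro are both halogens, so it remains open whether any group at this position can shift the number beyond the scatter. An amine or a carboxylic acid in place of the chloro group would test this.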